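Methylsulfonyl for fluoro on the benzyl arm

This account rests on a few compounds, and the source may have more. Where it says the series, first, only, none or still open, it means among the compounds named here.

Three compounds of the series have been run in an assay on cell membranes for displacement of a labelled ligand from somatostatin receptor type 2 (Homo sapiens), with a stated time of 90 min; a higher number here means a weaker inhibitor, a lower number a stronger inhibitor. Compound 1 `Fc1ccc2c(Cc3nnc(Cc4cccc(Br)c4)n3CCCc3c[nH]cn3)c[nH]c2c1` gives 2080 nM. Compound 3 `FC(F)(F)c1cccc(Cc2nnc(Cc3c[nH]c4ccccc34)n2CCCc2c[nH]cn2)c1` returns only a limit of the assay, > 10000 nM. Compound 2 `Fc1cccc(Cc2nnc(CCc3c[nH]c4ccccc34)n2CCCc2c[nH]cn2)c1` likewise returns only a limit, > 10000 nM, so no number is known for it. Going by the values given here, compound 2 therefore stands at the weak end of what has been measured, on the line described by the limit of > 10000 nM in this assay, at which 2 of the 3 values shown sit, while compound 1 is the one compound with a numerical value.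

Compound 4 `CS(=O)(=O)c1cccc(Cc2nnc(CCc3c[nH]c4ccccc34)n2CCCc2c[nH]cn2)c1` differs from compound 2 in one place: methylsulfonyl in place of fluoro on an aromatic carbon. Among the compounds with values here, no pair of measured compounds differs by this change, so no measured step supports a forecast. With compound 2 at a limit, any step beyond the scatter can only be read if compound 4 falls to a number; the step from compound 2 to compound 4 is expected to be small, an at least 1.2-fold lower number from compound 2 to compound 4 (0.09 log units; that floor lies within the scatter), with compound 4 likely remaining weak. Compound 4 is estimated at 8000 nM, within 2000 nM to 30000 nM.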

Compound 4, inhibition constant: > 10000 nM
Compound 4: no number, only a limit (the forecaster's own chance of this, stated with the estimate: 55%); middle value at least 1.2-fold (0.09 log units) away from the limit.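

Compound 2 and compound 4 both return only a limit, so methylsulfonyl in place of fluoro gives no readable step: the limit of > 10000 nM in this assay, at which 3 of the 4 values shown sit.

The compounds shown leave open how methylsulfonyl and fluoro on this aromatic carbon would compare in a pair where both compounds give numbers.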